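The compounds below may be only part of what the source reports. "The series", "measured", "known", "first", "only" and "open" are said of these compounds alone.

Compound 1, `c1ccc(CCc2ccc3c(NCCCNCc4ccco4)ccnc3c2)cc1`, gives 9.47 in a physicochemical assay for acid dissociation. Compound 2, `Fc1ccc(Oc2ccc3c(NCCCNCc4ccco4)ccnc3c2)cc1`, gives 9.28 in this assay. Compound 3, `Fc1ccc(Cc2ccc3c(NCCCNCc4ccco4)ccnc3c2)cc1`, gives 9.47 in this assay.

Compound 3 stands level with compound 1 at the digits shown (no change at the digits printed from compound 1 to compound 3 (within the scatter)), and its nearest other neighbour is compound 2 (a number 0.19 log units higher from compound 2 to compound 3 (within the scatter)). Compound 4 is `COc1ccccc1Oc1ccc2c(NCCCNCc3ccco3)ccnc2c1`; the change is 2-methoxyphenoxy in place of 4-fluorobenzyl on an aromatic carbon. Within the data shown here, two measured steps bear on it: an aryl ether in place of a carbon-linked aryl group on the same aromatic carbon gave a number 0.19 log units lower from compound 1 to compound 2 (within the scatter), and the reverse exchange gave a number 0.19 log units higher from compound 2 to compound 3 (within the scatter). Both lie within the scatter, so no step beyond the scatter is expected in this assay, at most a slight drift downward as a number 0.12 log units lower from compound 3 to compound 4 (within the scatter). Compound 4 is therefore estimated at 9.35, between 9.05 and 9.65.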

Compound 4, acid dissociation constant: 9.28
Compound 4: middle estimate off by 0.07 log units, on the high side, and the stated range covers the measured number.
By their numbers in this assay, from the lowest: compounds 2, 4, 1 and 3 (each within the scatter of the next).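

At this aromatic carbon, swapping the carbon-linked groups for 2-methoxyphenoxy stays within the scatter in this assay, both against 4-fluorobenzyl (a number 0.19 log units lower from compound 3 to compound 4 (within the scatter)) and against phenethyl (a number 0.19 log units lower from compound 1 to compound 4 (within the scatter)). Among the aryl ethers, the ring on the oxygen can also be exchanged, 2-methoxyphenyl for 4-fluorophenyl, with the result (no change at the digits printed from compound 2 to compound 4 (within the scatter)). No supporting evidence is available to explain these readings.

Still open, from the compounds shown here alone, is whether a different kind of group at this carbon, such as an amine or a carboxylic acid, would move the number beyond the scatter.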